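Aryl urea series: ethoxy to methyl, expected inhibition

The source may report more compounds than this note shows. Statements on the series, on what has been measured and on what is new or still open speak of the compounds shown alone.

Measured so far in a functional assay on the whole organism (strain albino) with Mus musculus as the target, at a dose of 100 mg/kg by the intraperitoneal route; on this read-out higher numbers stand for more inhibition at the one dose given (going by the name of the read-out) and lower numbers for less inhibition:
compound 1, `CCc1nc2ccccc2c(=O)n1NC(=O)Nc1ccccc1`, gives 54%
compound 2, `CCOc1ccc(NC(=O)Nn2c(CC)nc3ccccc3c2=O)cc1`, gives 50%
compound 3, `CCOc1ccc(NC(=O)Nn2c(-c3ccccc3)nc3ccccc3c2=O)cc1`, gives 53%

The three numbers sit close together. The step of a number 4 percentage points lower from compound 1 to compound 2 (within the scatter) and the step of a number 3 percentage points higher from compound 2 to compound 3 (within the scatter) are both within the scatter, so compound 2 cannot be separated from compound 1 or compound 3 on the numbers shown; the three readings are, for working purposes, one level.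

Compound 4, `CCc1nc2ccccc2c(=O)n1NC(=O)Nc1ccc(C)cc1`, is not yet measured. It differs from compound 2 in one place: methyl in place of ethoxy on an aromatic carbon. Going by the values given here, the step that bears most directly on this change is the one from compound 1 to compound 2, where ethoxy replaced hydrogen at this same place on the aryl ring and the read-out moved only a number 4 percentage points lower from compound 1 to compound 2 (within the scatter). The other step, a number 3 percentage points higher from compound 2 to compound 3 (within the scatter), concerns a different position but likewise stayed within the scatter. Among the compounds with values here, no step in this small set has moved the read-out beyond the scatter, so no step beyond the scatter is expected here either; the estimated change is a number 2 percentage points higher from compound 2 to compound 4 (within the scatter). Compound 4 is therefore expected to give about 52%, with a range from 38% to 66%.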

Compound 4, a percentage reported as inhibition, in the whole organism at one dose (the size of the read-out at that dose, not a potency): 55%
Estimate against measurement, compound 4: 3 percentage points below; low and high end bracket the measured number.
By their numbers in this assay, from the lowest: compounds 2, 3, 1 and 4 (each within the scatter of the next).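

On the aromatic carbon para to a large group, three substituents can now be compared in this assay: hydrogen, ethoxy and methyl. Methyl in place of ethoxy gives a number 5 percentage points higher from compound 2 to compound 4 (within the scatter), and methyl in place of hydrogen gives a number 1 percentage points higher from compound 1 to compound 4 (within the scatter), so, together with the earlier ethoxy step, no separation appears among the three groups at this position, with or without an oxygen in the group. Nothing available explains this flat reading.

Going by these compounds, whether an amine, a carboxylic acid or a longer chain at this position would move the read-out beyond the scatter stays open. Phenyl in place of ethyl is seen only with ethoxy on the aryl ring, in compound 3, and how it reads with hydrogen or methyl there is also open.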